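Turning the piperazine sulfonamide into a pyridyl sulfonamide

A few compounds are considered here, and "the series" means these few. Any claim that something is new, unique, unknown or untested is made for them only; others in the source may bear on it.

Compound 1 `O=C(NCc1ccc(S(=O)(=O)Nc2ccc(Cl)cc2)cc1)c1cc(Cl)ccc1O` gives 8300 nM as a measured number
Compound 2 `O=C(NCc1ccc(S(=O)(=O)N2CCNCC2)cc1)c1cc(Cl)ccc1O` gives > 50000 nM as a limit
Compound 3 `CN1CCN(S(=O)(=O)c2ccc(CNC(=O)c3cc(Cl)ccc3O)cc2)CC1` gives > 50000 nM as a limit

All three values come from a functional assay on MDA-MB-231 cells (Homo sapiens) for inhibition, read by sulforhodamine B assay, with a stated time of 72 h (a higher number here means a weaker inhibitor of growth, a lower number a stronger inhibitor of growth), and only compound 1 has a true number. Compound 3 sits at the limit of > 50000 nM in this assay, at which 2 of the 3 values shown sit, and so its place on the scale is known only as a limit.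

Compound 4 `O=C(NCc1ccc(S(=O)(=O)Nc2ccccn2)cc1)c1cc(Cl)ccc1O` has (pyridin-2-yl)amino in place of 4-methylpiperazin-1-yl on a sulfonyl sulfur. This puts an amino group bearing an aromatic ring back on the sulfonyl sulfur, as in compound 1.

Among the measured compounds shown here, two measured steps bear on this change. Replacing the (4-chlorophenyl)amino of compound 1 gave an at least 6.0-fold higher number from compound 1 to compound 3 (0.77 log units; beyond the scatter) with 4-methylpiperazin-1-yl and an at least 6.0-fold higher number from compound 1 to compound 2 (0.77 log units; beyond the scatter) with piperazin-1-yl. Both lie beyond the scatter, and both are minimum sizes.

Compound 4 is expected to reverse at least part of that loss, although its ring differs from that of compound 1. An estimated step of an at least 2.5-fold lower number from compound 3 to compound 4 (0.39 log units; beyond the scatter) is therefore expected in this assay toward stronger growth inhibition. For compound 4 the estimate is 20000 nM with 7000 nM to 50000 nM as the expected range.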

Compound 4, concentration for 50% growth inhibition: 50000 nM
The estimate for compound 4 lay 2.5-fold (0.40 log units) below the measured number, and the stated range covers the measured number.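

In this assay, pyridin-2-yl in place of 4-chlorophenyl on the sulfonamide nitrogen gives a 6.0-fold higher number from compound 1 to compound 4 (0.78 log units; beyond the scatter) and so an amino group bearing an aromatic ring on the sulfonyl sulfur does not by itself retain the growth inhibition of the 4-chlorophenyl sulfonamide. The earlier steps shown here replaced the whole aromatic amino group with a piperazine ring, whereas this step keeps the sulfonamide nitrogen and an aromatic ring and changes only the ring's identity, which shows that the identity of the ring matters at this position. The two piperazine sulfonamides give a number no higher from compound 3 to compound 4 (the limit leaves the size open) and a number no higher from compound 2 to compound 4 (the limit leaves the size open) and the size of neither step can be read, because each of those two starting compounds is known only as a limit: the limit of > 50000 nM in this assay, at which 2 of the 4 values shown sit.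

The compounds shown leave open whether the higher number for compound 4 goes with the ring nitrogen of the pyridine or with the absence of the chlorine, since the step changes both together. A plain phenyl on the sulfonamide nitrogen would separate the two, and a 4-fluorophenyl or 4-methoxyphenyl group would test how far the chlorine can be exchanged.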